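This account rests on a few compounds, and the source may have more. Where it says the series, first, only, none or still open, it means among the compounds named here.

Working notes on the series. All compounds here share one core and differ only in the group on the amide-type nitrogen. Compound 1 `O=C(CCSc1nnc(-c2ccncc2)s1)Nc1ccccc1` carries a phenyl there. In an ADME assay on HepG2 cells (Homo sapiens) for cytotoxicity, with a stated time of 3 days (on this read-out higher numbers stand for lower toxicity in this test and lower numbers for higher toxicity in this test), compound 1 gives > 50000 nM, which is a limit of the test and not a number. Compound 2 `O=C(CCSc1nnc(-c2ccncc2)s1)Nc1ccc(Cl)cc1Cl` carries a 2,4-dichlorophenyl in place of phenyl. In this assay compound 2 gives > 50000 nM, again a limit. Compound 3 `O=C(CCSc1nnc(-c2ccncc2)s1)NCc1ccccc1Cl` carries a 2-chlorobenzyl. In this assay compound 3 gives > 50000 nM, also a limit. Compound 3 therefore stands only at a limit, and no number is known for it. The steps a step that the two limits leave unreadable from compound 1 to compound 2, a step that the two limits leave unreadable from compound 1 to compound 3 and a step that the two limits leave unreadable from compound 2 to compound 3 are all unreadable, since (the limit of > 50000 nM in this assay, at which 3 of the 3 values shown sit).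

Compound 4 `O=C(CCSc1nnc(-c2ccncc2)s1)NCc1ccccc1` is the next member. Against compound 3 the difference is hydrogen in place of chloro on an aromatic carbon. For the measured compounds named here, none of the measured steps can be read in size, so none gives a direction for this one; all that is seen is that every change on this nitrogen so far has left the value at the limit. The step that the limit leaves unreadable from compound 3 to compound 4 is therefore expected to be nothing beyond the scatter. For compound 4 the expected value in this assay is 70000 nM, with a range from 30000 nM to 200000 nM, most likely reported again as a limit.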

Compound 4, half-maximal cytotoxic concentration: 14000 nM
Estimate against measurement, compound 4: 5.0-fold (0.70 log units) above; measured number below the stated range.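

In this assay, for the compounds shown here, the group on the amide-type nitrogen now shows a readable influence on the read-out: hydrogen in place of chloro on the aromatic carbon gives an at least 3.5-fold lower number from compound 3 to compound 4 (0.55 log units; beyond the scatter), so the chloro of the 2-chlorobenzyl makes a difference that the earlier compounds could not reveal. Benzyl also stands apart from both anilide-type groups, with an at least 3.5-fold lower number from compound 2 to compound 4 (0.55 log units; beyond the scatter) and an at least 3.5-fold lower number from compound 1 to compound 4 (0.55 log units; beyond the scatter), which leaves compound 4 with the lowest number in the series and the highest toxicity in this test. These three steps give only a minimum size, and the steps among compound 1, compound 2 and compound 3 remain unreadable: the limit of > 50000 nM in this assay, at which 3 of the 4 values shown sit.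

Going by these compounds, how far compound 1, compound 2 and compound 3 actually lie from compound 4 stays open, as does whether the change from phenyl to benzyl and the loss of chloro carry the same weight in other members. Also open, on these data alone, is whether a fluoro or a methoxy on the benzyl ring, an amine on that ring, or a phenethyl group with its longer chain would sit with compound 4 or with the other three.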